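Methylating the Phenol of Compound 2

A few compounds are considered here, and "the series" means these few. Any claim that something is new, unique, unknown or untested is made for them only; others in the source may bear on it.

Compound 1 `COc1cc(O)ccc1N1CCN(CC(O)COc2ccc(O)c3ccccc23)CC1` gives only an assay limit, > 50000 nM, in a functional assay on KK-47 cells for antiproliferative activity against KK-47 cell line (Homo sapiens), read by MTT assay, with a stated time of 48 h; on this read-out lower numbers stand for stronger inhibition and higher numbers for weaker inhibition.
Compound 2 `Oc1ccccc1N1CCN(CC(O)COc2ccc(O)c3ccccc23)CC1` gives 33000 nM in this assay.
Compound 3 `Oc1ccccc1N1CCN(CC(O)COc2cccc3ccccc23)CC1` gives 18900 nM in this assay.

Among the two numbers in this assay, compound 2 stands highest; its nearest neighbour is compound 3, with a 1.7-fold lower number from compound 2 to compound 3 (0.24 log units; within the scatter). Compound 1 sits at the limit of > 50000 nM in this assay, at which 1 of the 3 values shown sits. Compound 4 `COc1ccccc1N1CCN(CC(O)COc2ccc(O)c3ccccc23)CC1` differs from compound 2 by methyl in place of hydrogen on an oxygen on an aromatic ring. For the measured compounds named here, no measured step alters exactly this oxygen; the nearest precedents are an at least 1.5-fold lower number from compound 1 to compound 2 (0.18 log units; that floor lies within the scatter) and a 1.7-fold lower number from compound 2 to compound 3 (0.24 log units; within the scatter), both small. A step no larger than the scatter is therefore expected, a 1.3-fold lower number from compound 2 to compound 4 (0.12 log units; within the scatter). Compound 4 is estimated at 25000 nM, between 8000 nM and 80000 nM.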

Compound 4, half-maximal inhibitory concentration: 17600 nM
For compound 4 the middle estimate is 1.4-fold (0.15 log units) above the measured one; measured number inside the range.
By their numbers in this assay, from the lowest: compounds 4, 3 and 2 (each within the scatter of the next). At a limit, above all of these: compound 1.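

Methyl in place of hydrogen on an oxygen on an aromatic ring, hydroxy to methoxy, gives a 1.9-fold lower number from compound 2 to compound 4 (0.27 log units; within the scatter), so in this assay the free hydroxy of the 2-hydroxyphenyl group is not needed for the activity seen. Hydrogen in place of hydroxy on an aromatic carbon gives the only new step beyond the scatter, read from a limit: an at least 2.8-fold lower number from compound 1 to compound 4 (0.45 log units; beyond the scatter). Set against the same change on another core, its size remains unsettled: the same change on two cores in this assay, a 1.7-fold lower number (0.24 log units; within the scatter) from compound 2 to compound 3 and an at least 2.8-fold lower number (0.45 log units; beyond the scatter) from compound 1 to compound 4; the limit leaves it open whether they differ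

The compounds shown leave open whether ethyl or a longer chain on this oxygen, or an amine in place of it, would keep the number in this range.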